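Nitrophenyl for Pyridinyl on a Dienone Chain

The compounds below may be only part of what the source reports. "The series", "measured", "known", "first", "only" and "open" are said of these compounds alone.

Compound 1, `O=C(/C=C/c1ccc(Oc2cc(=O)oc3ccccc23)cc1)/C=C/c1cccnc1`, gives 17400 nM in a functional assay on SGC-7901 cells (Homo sapiens) for antiproliferative activity, read by MTT assay, with a stated time of 48 h; a higher number here means a weaker inhibitor, a lower number a stronger inhibitor.
Compound 2, `O=C(/C=C/c1ccc(Cl)cc1)/C=C/c1ccc(Oc2cc(=O)oc3ccccc23)cc1`, gives 48300 nM in this assay.
Compound 3, `COc1cc(OC)c2c(=O)c(OCCCOc3ccccc3/C=C/C(=O)/C=C/c3ccccn3)c(-c3cc(OC)c(OC)c(OC)c3)oc2c1`, gives 1080 nM in this assay.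

Compound 3 stands lowest of the three numbers; the nearest is compound 1 and the furthest is compound 2, both beyond the scatter. Compound 4, `COc1cc(OC)c2c(=O)c(OCCCOc3ccccc3/C=C/C(=O)/C=C/c3cccc([N+](=O)[O-])c3)c(-c3cc(OC)c(OC)c(OC)c3)oc2c1`, differs from compound 3 in one place: 3-nitrophenyl in place of pyridin-2-yl on a double-bonded chain carbon bound to a double-bonded chain carbon. For the measured compounds named here, the one measured step that bears on this, an aromatic heterocycle with one nitrogen giving way to a carbon-only ring, is a 2.8-fold higher number from compound 1 to compound 2 (0.44 log units; beyond the scatter), a modest weakening. On that basis a step of similar size and the same direction is expected in this assay, though the swap here is not identical. Compound 4 is therefore estimated at 2200 nM, within 700 nM to 7000 nM, a step of a 2.0-fold higher number from compound 3 to compound 4 (0.31 log units; beyond the scatter).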

Compound 4, half-maximal inhibitory concentration: 5400 nM
The estimate for compound 4 lay 2.5-fold (0.39 log units) below the measured number, and the stated range covers the measured number.
By their numbers in this assay, from the lowest: compound 3; then compound 4; then compound 1; then compound 2.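

In this assay, swapping pyridin-2-yl for 3-nitrophenyl on a double-bonded chain carbon bound to a double-bonded chain carbon gives a 5.0-fold higher number from compound 3 to compound 4 (0.70 log units; beyond the scatter). A carbon-only ring replacing a pyridinyl ring thus raises the number on a second core, in the same direction as a 2.8-fold higher number from compound 1 to compound 2 (0.44 log units; beyond the scatter), although the groups and their ring positions differ. No evidence is available to explain this loss. The compounds shown leave open whether the change follows from losing the ring nitrogen or from adding the nitro group. Nor do they show where a plain phenyl or a 3-aminophenyl ring would fall at this place.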